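Compound 2 to compound 3: 4-nitrophenyl for 2-methylphenyl

A few compounds are considered here, and "the series" means these few. Any claim that something is new, unique, unknown or untested is made for them only; others in the source may bear on it.

In a functional assay on B16 cells (Mus musculus) for antiproliferative activity, read by MTT assay, with a stated time of 24 h (on this read-out higher numbers stand for weaker inhibition and lower numbers for stronger inhibition), compound 1 (`COc1cc(OC)c(-c2coc3cc(OCC=C(C)C)ccc3c2=O)cc1OC`) gives 1090 nM and compound 2 (`COc1cc(OC)c(-c2coc3cc(OCc4ccccc4C)ccc3c2=O)cc1OC`) gives 2150 nM within the scatter of compound 1. Compound 3 (`COc1cc(OC)c(-c2coc3cc(OCc4ccc([N+](=O)[O-])cc4)ccc3c2=O)cc1OC`) differs from compound 2 at one place (4-nitrophenyl in place of 2-methylphenyl on a saturated chain carbon bound to an oxygen on an aromatic ring), with 4-nitrophenyl in place of 2-methylphenyl on a saturated chain carbon bound to an oxygen on an aromatic ring. Among the compounds with values here, the only measured step (a 2.0-fold higher number from compound 1 to compound 2 (0.30 log units; within the scatter)) changed that same place and stayed within the scatter, but no measured compound holds 4-nitrophenyl. No step beyond the scatter is therefore expected in this assay for this change. The estimated step (a 1.1-fold lower number from compound 2 to compound 3 (0.03 log units; within the scatter)) is correspondingly expected to be small. For compound 3 the estimate is 2000 nM (expected range 700 nM to 6000 nM).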

Compound 3, half-maximal inhibitory concentration: > 10000 nM
Compound 3 gave a limit, no number (the forecaster's own chance of this, stated with the estimate: 5%); middle value at least 5.0-fold (0.69 log units) away from the limit.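

In this assay, compound 3 gives a limit of the assay, not a number: the limit of > 10000 nM in this assay, at which 1 of the 3 values shown sits. The place on a saturated chain carbon bound to an oxygen on an aromatic ring had so far shown only a step within the scatter, but it now responds to the group it carries. With 4-nitrophenyl the result is an at least 4.6-fold higher number from compound 2 to compound 3 (0.66 log units; beyond the scatter) and an at least 9.1-fold higher number from compound 1 to compound 3 (0.96 log units; beyond the scatter).

The compounds shown do not separate the nitro group from the place it holds on the phenyl ring. A 4-methylphenyl or a 4-aminophenyl group on the same carbon would bear on that question.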